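Compound 4: will it rise off the limit?

The source may hold more compounds than are shown below. What is called first, only, known or untested is meant among the compounds shown, and "the series" means these compounds.

Values so far in a physicochemical assay for solubility, with a stated time of 24 h, at pH 4.5 (a higher number here means a more soluble compound, a lower number a less soluble compound), are these:
- compound 1 `O=C(NC[C@@H]1[C@H]2CN(C(=O)/C=C/c3cc(Cl)cc(Cl)c3)C[C@@H]12)c1ccc2[nH]c(=O)oc2c1` gives < 1 ug/mL as a limit
- compound 2 `O=C(NC[C@@H]1[C@H]2CN(C(=O)C3CC3c3cc(Cl)cc(Cl)c3)C[C@@H]12)c1ccc2[nH]c(=O)oc2c1` gives < 1 ug/mL as a limit
- compound 3 `O=C(NC[C@@H]1[C@H]2CN(C(=O)OCc3cc(C(F)(F)F)cc(C(F)(F)F)c3)C[C@@H]12)c1ccc2[nH]c(=O)oc2c1` gives < 1 ug/mL as a limit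

For compound 1 the reading < 1 ug/mL is a limit of the assay and not a number. For the measured compounds named here, the series so far shows the limit of < 1 ug/mL in this assay, at which 3 of the 3 values shown sit, and so gives no true number for any compound.

Compound 4 `Cc1cc(COC(=O)N2C[C@@H]3[C@@H](CNC(=O)c4ccc5[nH]c(=O)oc5c4)[C@@H]3C2)no1` has not yet been measured. It differs from compound 1 in one place: (5-methyl-1,2-oxazol-3-yl)methoxy in place of 2-(3,5-dichlorophenyl)ethenyl on a carbonyl carbon and the rest of the structure stays the same. In words, (5-methyl-1,2-oxazol-3-yl)methoxy stands in place of 2-(3,5-dichlorophenyl)ethenyl on a carbonyl carbon.

Going by the values given here, only one measured step touches this place. It is a step that the two limits leave unreadable from compound 1 to compound 2 and it gives no size to build on. Compound 1 gives < 1 ug/mL as a limit, so any readable number for compound 4 would have to lie upward. Among the compounds with values here, an upward move is therefore expected, although no measured step fixes its size. The estimated step is an at least 8.0-fold higher number from compound 1 to compound 4 (0.90 log units; beyond the scatter) and it rests on the structural change alone. For compound 4 the expected value is 8 ug/mL with an estimated range from 1.5 ug/mL to 40 ug/mL and a real chance of another limit.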

Compound 4, solubility: > 93 ug/mL
Compound 4: a limit, no number; the forecaster's own chance of this, stated with the estimate: 20%; middle value at least 11-fold (1.06 log units) away from the limit.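

In this assay, the group on this carbonyl carbon proves able to carry the reading far from the floor seen so far: (5-methyl-1,2-oxazol-3-yl)methoxy in place of 2-(3,5-dichlorophenyl)ethenyl gives an at least 93-fold higher number from compound 1 to compound 4 (1.96 log units; beyond the scatter), and the same group in place of the cyclopropane-bearing group gives an at least 93-fold higher number from compound 2 to compound 4 (1.96 log units; beyond the scatter). Compound 4 gives > 93 ug/mL, which is a limit, so the series now has an upper end as well as a lower one: the limit of > 93 ug/mL in this assay, at which 1 of the 4 values shown sits. Compound 3 also joins its group to this carbonyl carbon through an oxygen, yet it gives < 1 ug/mL, which is also a limit: the limit of < 1 ug/mL in this assay, at which 3 of the 4 values shown sit.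

From the compounds shown here alone, none of the four compounds has a true number, so the real size of both large steps stays unknown, and the steps among the compounds at the lower limit cannot be read. Open too, going by these compounds, is whether the oxazole ring matters or only the loss of the dichlorophenyl ring, a question that a plain unsubstituted phenyl ring or a short chain ending in an amine at this place could help to separate.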